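The compounds below may be only part of what the source reports. "The series", "measured", "known", "first", "only" and "open" are said of these compounds alone.

Going by the values given here, compound 2 `CCCOc1cccnc1-c1ccc(C(=O)Nc2ccc(C(C)(C)C)cc2)cc1` is the one measured compound that gives an actual number in a functional assay for antagonist activity at transient receptor potential cation channel subfamily V member 1 (Homo sapiens), read by FLIPR (on this read-out lower numbers stand for stronger inhibition and higher numbers for weaker inhibition), where compound 2 gives 62 nM. Compound 1 `Cc1cccnc1-c1ccc(C(=O)Nc2ccc(F)cc2)cc1` reaches only a limit of the assay, at > 4000 nM. Compound 3 `CC(C)(C)c1ccc(NC(=O)c2ccc(-c3ncccc3C(=N)N)cc2)cc1` likewise stops at a limit, at > 4000 nM. So two of the three results sit at the limit of > 4000 nM in this assay, at which 2 of the 3 values shown sit, and compound 2 stands alone with a measured value.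

Compound 4 `CN(C)Cc1cccnc1-c1ccc(C(=O)Nc2ccc(C(C)(C)C)cc2)cc1` differs from compound 2 in a single place: (dimethylamino)methyl in place of propoxy on an aromatic carbon. Among the compounds with values here, one measured step bears on this, since it also removes the propoxy group of compound 2 at the same place: an at least 64-fold higher number from compound 2 to compound 3 (1.80 log units; beyond the scatter). Within the data shown here, there a nitrogen-bearing group entering sent the value from the only number straight to the limit. Among the measured compounds shown here, the (dimethylamino)methyl group entering compound 4 is a different nitrogen-bearing group, so the outcome is uncertain, but the one comparable change was a large loss. For the measured compounds named here, compound 1 differs from compound 2 in two places, not one, and no single step joins them.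

A weakening step is therefore expected, estimated at an 11-fold higher number from compound 2 to compound 4 (1.05 log units; beyond the scatter). Compound 4 is expected to give 700 nM, within a range from 120 nM to 4000 nM.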

Compound 4, half-maximal inhibitory concentration: 746 nM
Compound 4: middle estimate off by 1.1-fold (0.03 log units), on the low side; measured number inside the range.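

Going by these compounds alone, the step of a 12-fold higher number from compound 2 to compound 4 (1.08 log units; beyond the scatter) in this assay is the first change at this position with a real number at both ends, so the size of the loss can be stated rather than only bounded. Propoxy and (dimethylamino)methyl have the same counts of heavy atoms, hydrogen-bond donors and acceptors and the same lack of net charge, so these counts alone do not separate compound 2 from compound 4. The nitrogen-bearing groups at this place also differ from each other, and a nitrogen-bearing group here does not always end at the limit, as an at least 5.3-fold lower number from compound 3 to compound 4 (0.72 log units; beyond the scatter) shows, although compound 3 gives only a limit, so this step has a minimum size and no exact one: the limit of > 4000 nM in this assay, at which 2 of the 4 values shown sit.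

From the compounds shown here alone, what remains open is whether the loss from propoxy follows from removing the oxygen, from adding the nitrogen, or from both. A plain butyl chain at this place would test the oxygen, and a primary amine such as aminomethyl or a longer alkoxy chain such as butoxy would show how far the result depends on the group's exact make-up.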